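Shared-core series: cyclopentylamino to (2-methoxyethyl)amino

The compounds below may be only part of what the source reports. "The series", "measured", "known", "first", "only" and "open" are said of these compounds alone.

Measured so far in a functional assay on CHO cells for antagonist activity at adenosine receptor A2b (Homo sapiens); on this read-out lower numbers stand for stronger inhibition and higher numbers for weaker inhibition:
- compound 1, `COc1ccc(CNc2ncc(C(=O)O)c3nc(-c4ccco4)nn23)cc1OC`: > 30000 nM.
- compound 2, `O=C(Nc1ncc(C(=O)O)c2nc(-c3ccco3)nn12)NC1CCCCC1`: > 30000 nM.
- compound 3, `CCOC(=O)c1cnc(NC2CCCC2)n2nc(-c3ccco3)nc12`: 4620 nM.

For compound 1 the value is a limit of the assay, not a number. For compound 2 the value is likewise a limit. Compound 3 therefore stands alone with a measured number in this assay, the other two values sitting at the limit of > 30000 nM in this assay, at which 2 of the 3 values shown sit.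

Compound 4, `CCOC(=O)c1cnc(NCCOC)n2nc(-c3ccco3)nc12`, differs from compound 3 in one place: 2-methoxyethyl in place of cyclopentyl on a nitrogen on an aromatic ring. Among the measured compounds shown here, no measured step covers this change, so no measured direction is available. The step from compound 3 to compound 4 is expected to be small, with a slight loss of potency at most, as a 1.7-fold higher number from compound 3 to compound 4 (0.24 log units; within the scatter). Compound 4 is therefore estimated at 8000 nM, with a range from 2500 nM to 30000 nM.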

Compound 4, inhibition constant: > 10000 nM
Compound 4: only a limit was reported (the forecaster's own chance of this, stated with the estimate: 25%); middle value at least 1.2-fold (0.09 log units) away from the limit.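

In this assay the substituent on the nitrogen gives the series its first readable step, with 2-methoxyethyl in place of cyclopentyl: an at least 2.1-fold higher number from compound 3 to compound 4 (0.33 log units; beyond the scatter). Compound 4 carries a limit of the assay, not a number: the limit of > 10000 nM in this assay, at which 1 of the 4 values shown sits. The true size of the weakening therefore stays unknown, and compound 3 remains the only compound shown with a measured number.

The change removes the ring and adds an ether oxygen together, and the two effects cannot be separated here. A butyl chain or a cyclohexyl group on that nitrogen, with the ethyl ester kept, would tell them apart.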